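Cytotoxicity series: ether variation on the biaryl

A few compounds are considered here, and "the series" means these few. Any claim that something is new, unique, unknown or untested is made for them only; others in the source may bear on it.

Measured compounds:
compound 1, `CC(=O)Nc1cccc(-c2ccc(C(=O)N(Cc3cccc(OCCCCCC(=O)O)c3)C(C)C)cc2)c1` — an ADME assay on HEK293 cells (Homo sapiens) for cytotoxicity, read by CellTiter-Glo and resazurin assay, with a stated time of 72 h; a higher number here means that more compound is needed for the effect, a lower number that less compound is needed: > 26000 nM
compound 2, `CC(C)COc1cccc(-c2ccc(C(=O)N(Cc3cccc(OCCCCCC(=O)O)c3)C(C)C)cc2)c1` — this assay: > 26000 nM
compound 3, `CC(C)N(Cc1cccc(OCCCCCC(=O)O)c1)C(=O)c1ccc(-c2cccc(Oc3ccccc3)c2)cc1` — this assay: > 18700 nM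

All three values are limits of the assay, not numbers. For compound 1 the value > 26000 nM is a limit. For compound 2 the value > 26000 nM is a limit. For compound 3 the value > 18700 nM is a limit, and it sits at the limit of > 18700 nM in this assay, at which 1 of the 3 values shown sits, while the other two sit at the limit of > 26000 nM in this assay, at which 2 of the 3 values shown sit. The steps a step that the two limits leave unreadable from compound 1 to compound 2, a step that the two limits leave unreadable from compound 1 to compound 3 and a step that the two limits leave unreadable from compound 2 to compound 3 are therefore not readable in size or direction; none of them shows cytotoxicity within the tested range.

Compound 4, `CC(C)N(Cc1cccc(OCCCCCC(=O)O)c1)C(=O)c1ccc(-c2cccc(OCc3ccccc3)c2)cc1`, is not yet measured in this assay. It differs from compound 3 by benzyl in place of phenyl on an oxygen on an aromatic ring. The step from compound 2 to compound 3 is the nearest comparison, another exchange on the same oxygen, and it too gave only limits. The expectation for compound 4 is therefore no readable step, a step that the limit leaves unreadable from compound 3 to compound 4, with the value most likely again reported as a limit. Compound 4 is estimated at 30000 nM, within 15000 nM to 60000 nM.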

Compound 4, half-maximal effective concentration: > 26000 nM
Compound 4: only a limit was reported; the forecaster's own chance of this, stated with the estimate: 85%; the middle value does not contradict the limit.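

In this assay compound 4 gives > 26000 nM, a limit and not a number, so its steps from compound 1, compound 2 and compound 3 cannot be read. The compounds shown leave open at what concentration, if any, these four compounds become cytotoxic.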